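Swapping the amide aryl group on a quinoline-type core

This account rests on a few compounds, and the source may have more. Where it says the series, first, only, none or still open, it means among the compounds named here.

Measured compounds:
- compound 1, `CCN1CCN(c2cc(C)c3cc(NC(=O)c4ccccc4C)ccc3n2)CC1`: 10900 nM
- compound 2, `CCN1CCN(c2cc(C)c3cc(NC(=O)c4ccco4)ccc3n2)CC1`: 41200 nM
- compound 3, `CCN1CCN(c2cc(C)c3cc(NC(=O)c4ccc[nH]4)ccc3n2)CC1`: 14700 nM

All three share one core and differ only in the group on the carbonyl carbon of the amide. In a functional assay on MCF7 cells (Homo sapiens) for antiproliferative activity, read by MTT assay, with a stated time of 72 h (a lower number here means a stronger inhibitor, a higher number a weaker inhibitor), compound 3 sits second highest of the three numbers: against compound 1 the step of a 1.3-fold higher number from compound 1 to compound 3 (0.13 log units; within the scatter) lies within the scatter, while against compound 2 the step of a 2.8-fold lower number from compound 2 to compound 3 (0.45 log units; beyond the scatter) is modest. Compound 4, `CCN1CCN(c2cc(C)c3cc(NC(=O)c4ccccc4Br)ccc3n2)CC1`, is not yet measured; its change is 2-bromophenyl in place of 1H-pyrrol-2-yl on a carbonyl carbon. The nearest guide is the return from a five-membered ring to a six-membered ring carrying one substituent, which in a 1.3-fold higher number from compound 1 to compound 3 (0.13 log units; within the scatter) read as no change beyond the scatter. Compound 4 is therefore expected to give 11000 nM, within 4500 nM to 27000 nM, a step of a 1.3-fold lower number from compound 3 to compound 4 (0.13 log units; within the scatter) that is not expected to exceed the scatter.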

Compound 4, half-maximal inhibitory concentration: 27500 nM
Estimate against measurement, compound 4: 2.5-fold (0.40 log units) below; the whole stated range lies below it.
By their numbers in this assay, from the lowest: compounds 1, 3, 4 and 2 (each within the scatter of the next, the first and the last beyond it).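

In this assay the group on the carbonyl carbon responds to a single substituent on the phenyl ring: bromo in place of methyl gives a 2.5-fold higher number from compound 1 to compound 4 (0.40 log units; beyond the scatter) and so separates 2-bromophenyl from 2-methylphenyl. By contrast, a 1.9-fold higher number from compound 3 to compound 4 (0.27 log units; within the scatter) and a 1.5-fold lower number from compound 2 to compound 4 (0.18 log units; within the scatter) both stay within the scatter, so 2-bromophenyl cannot be told apart from either five-membered ring, although those two rings differ by a 2.8-fold lower number from compound 2 to compound 3 (0.45 log units; beyond the scatter) as a modest step. Nothing available here accounts for the bromo and methyl difference.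

From the compounds shown here alone, whether chloro, methoxy or an amine on that phenyl ring would follow bromo or methyl remains open.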